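A few compounds are considered here, and "the series" means these few. Any claim that something is new, unique, unknown or untested is made for them only; others in the source may bear on it.

Compound 3 `CC(O)c1cccc(C(=O)N[C@@H](C)Cn2ccc(-c3ccc(C#N)c(Cl)c3)n2)c1` belongs to a small set of compounds tested in an ADME assay on PC-3 cells (Homo sapiens) for cytotoxicity, read by CCK-8 assay, with a stated time of 6 days; on this read-out lower numbers stand for stronger inhibition and higher numbers for weaker inhibition. In this assay compound 3 gives > 30000 nM, which is a limit of the assay rather than a number. Compound 1 `CC(=O)c1cc(C(=O)N[C@@H](C)Cn2ccc(-c3cc(F)c(C#N)c(Cl)c3)n2)n[nH]1` gives > 30000 nM in this assay, again a limit. Compound 2 `C[C@@H](Cn1ccc(-c2ccc(C#N)c(Cl)c2)n1)NC(=O)c1ccccc1` gives > 30000 nM in this assay, also a limit. Among the measured compounds shown here, the only single change among the measured compounds, a step that the two limits leave unreadable from compound 2 to compound 3, cannot be read in size, since both ends sit at a limit. For the measured compounds named here, the whole set therefore rests on (the limit of > 30000 nM in this assay, at which 3 of the 3 values shown sit), and no measured step shows a real effect of any group on this read-out.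

Compound 4 `CC(O)c1ccc(C(=O)N[C@@H](C)Cn2ccc(-c3ccc(C#N)c(Cl)c3)n2)cc1` differs from compound 3 in one place: 4-(1-hydroxyethyl)phenyl in place of 3-(1-hydroxyethyl)phenyl on a carbonyl carbon. Going by the values given here, no measured step bears directly on this rearrangement of the same atoms. Given that compound 3 sits at the limit, compound 4 is expected to sit there too, so the step of a number no higher from compound 3 to compound 4 (the limit leaves the size open) is estimated to be none beyond the scatter. Compound 4 is estimated at 30000 nM, with a range from 10000 nM to 100000 nM.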

Compound 4, half-maximal inhibitory concentration: > 30000 nM
Compound 4: a limit, no number; the forecaster's own chance of this, stated with the estimate: 85%; the middle value lies on the limit itself.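

The steps from compound 2 to compound 3, from compound 3 to compound 4 and from compound 2 to compound 4 cannot be read in size, because each end is a limit rather than a number: the limit of > 30000 nM in this assay, at which 4 of the 4 values shown sit.

The compounds shown leave open whether adding the 1-hydroxyethyl group, or changing 3-(1-hydroxyethyl)phenyl to 4-(1-hydroxyethyl)phenyl, alters this read-out at all.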